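The source may report more compounds than this note shows. Statements on the series, on what has been measured and on what is new or still open speak of the compounds shown alone.

Compound 1 `CCCOP(=O)(O)OCCSC(=S)N1CCCCC1`: 68000 nM
Compound 2 `CCCCCCCCOP(=O)(O)OCCSC(=S)N1CCCCC1`: 11900 nM
Compound 3 `CCCCCCOP(=O)(O)OCCSC(=S)N1CCCCCC1`: 17200 nM

All three values come from a functional assay on MDA-MB-231 cells (Homo sapiens) for inhibition, read by MTT assay, with stated times of 18 h and 4 h; on this read-out lower numbers stand for stronger inhibition and higher numbers for weaker inhibition. On these numbers, compound 3 stands within the usual scatter of compound 2, while compound 1 has a clearly higher number, meaning weaker inhibition.

The next compound, compound 4 `CCCCCCOP(=O)(O)OCCSC(=S)N1CCCCC1`, keeps the hexyl chain of compound 3 and changes one group: piperidin-1-yl in place of azepan-1-yl on a thiocarbonyl carbon.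

For the measured compounds named here, no measured pair isolates this ring change. Going by the values given here, the only measured step, a 5.7-fold lower number from compound 1 to compound 2 (0.76 log units; beyond the scatter), changes the chain instead and bears on this question only indirectly. It does show that compounds with the piperidin-1-yl group respond to chain length. The hexyl chain of compound 4 is longer than the propyl chain of compound 1 and shorter than the octyl chain of compound 2, so a value nearer compound 2 at 11900 nM seems likely. In this assay, no change beyond the scatter is expected. The estimated step is a 1.2-fold higher number from compound 3 to compound 4 (0.07 log units; within the scatter). Compound 4 is expected at about 20000 nM, with an estimated range of 10000 nM to 40000 nM.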

Compound 4, half-maximal inhibitory concentration: 85000 nM
Compound 4: the middle estimate sits 4.3-fold (0.63 log units) below what was measured, outside the stated range (above it).
By their numbers in this assay, from the lowest: compounds 2 and 3 (each within the scatter of the next); then compounds 1 and 4 (each within the scatter of the next).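

For the compounds shown here, with the hexyl chain held fixed, piperidin-1-yl in place of azepan-1-yl on the thiocarbonyl carbon gives a 4.9-fold higher number from compound 3 to compound 4 (0.69 log units; beyond the scatter) and is the first measured sign that this ring matters, with the seven-membered ring going with stronger inhibition. Among the compounds carrying piperidin-1-yl, the chain effect is not a smooth trend: shortening octyl to hexyl gives a 7.1-fold higher number from compound 2 to compound 4 (0.85 log units; beyond the scatter) while lengthening propyl to hexyl gives a 1.3-fold higher number from compound 1 to compound 4 (0.10 log units; within the scatter) and leaves the number within the scatter, with only the octyl compound standing apart. Nothing measured here explains either result.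

Azepan-1-yl appears here only with the hexyl chain, and whether its advantage holds with a propyl or octyl chain stays open. Also open, from the compounds shown here alone, is what a pyrrolidine or morpholine ring would give on the thiocarbonyl carbon.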